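Replacing benzyl with 4-bromophenyl on compound 3

A few compounds are considered here, and "the series" means these few. Any claim that something is new, unique, unknown or untested is made for them only; others in the source may bear on it.

Measured so far:
Compound 1 `O=C(O)c1cn(C2CC2)c2cc(N3CCN(C(=O)CCSc4nnnn4-c4ccc(Br)cc4)CC3)c(F)cc2c1=O`: <= 100 nM
Compound 2 `CCn1cc(C(=O)O)c(=O)c2cnc(N3CCN(C(=O)CCSc4nnnn4-c4ccc(F)c(F)c4F)CC3)nc21`: <= 100 nM
Compound 3 `CCn1cc(C(=O)O)c(=O)c2cnc(N3CCN(C(=O)CCSc4nnnn4Cc4ccccc4)CC3)nc21`: <= 100 nM

In a functional assay on SiHa cells (Homo sapiens) for inhibition, read by sulforhodamine B assay, with a stated time of 48 h (a higher number here means a weaker inhibitor of growth, a lower number a stronger inhibitor of growth), compound 3 gives <= 100 nM, which is a limit and not a number. The other compounds stand no differently, with the limit of <= 100 nM in this assay, at which 3 of the 3 values shown sit. Compound 4 `CCn1cc(C(=O)O)c(=O)c2cnc(N3CCN(C(=O)CCSc4nnnn4-c4ccc(Br)cc4)CC3)nc21` carries 4-bromophenyl in place of benzyl on an aromatic nitrogen. The closest measured change is a step that the two limits leave unreadable from compound 2 to compound 3, and it offers no size to work from. Compound 1 also carries 4-bromophenyl, on a different core, and compound 1 gives <= 100 nM, again a limit. No clear move in either direction is therefore expected in this assay. The expected change is a step that the limit leaves unreadable from compound 3 to compound 4. Compound 4 is estimated at 70 nM, with an expected range of 20 nM to 250 nM.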

Compound 4, concentration for 50% growth inhibition: 80 nM
Estimate against measurement, compound 4: 1.1-fold (0.06 log units) below; the measured number falls inside the stated range.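

The steps from compound 3 to compound 4 and from compound 2 to compound 4 cannot be read, since compound 2 and compound 3 carry only a limit: the limit of <= 100 nM in this assay, at which 3 of the 4 values shown sit.

The compounds shown leave open whether 4-bromophenyl in place of benzyl or 2,3,4-trifluorophenyl changes growth inhibition at all.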